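Compound 4 and the limit of compound 3

The source may hold more compounds than are shown below. What is called first, only, known or untested is meant among the compounds shown, and "the series" means these compounds.

Measured so far in a functional assay on J774 cells (Mus musculus) for cytotoxicity, with a stated time of 48 h; a higher number here means a weaker inhibitor, a lower number a stronger inhibitor:
Compound 1 `CC(C)(C)OC(=O)NCC(=O)N1CCC[C@H](C(=O)N2[C@H](C(=O)O)[C@H]2C(=O)O)C1`: "not determined" (no result reported)
Compound 2 `CC(C)(C)OC(=O)NCC(=O)N1CCC[C@H]1C(=O)N1[C@H](C(=O)OCc2ccccc2)[C@H]1C(=O)OCc1ccccc1`: > 100000 nM (a limit, not a number)
Compound 3 `CC(C)(C)OC(=O)NCC(=O)N1CCC[C@@H]1C(=O)N1[C@H](C(=O)OCc2ccccc2)[C@H]1C(=O)OCc1ccccc1`: > 100000 nM (a limit, not a number)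

The numbers shown give no exact value for any of these compounds. Compound 3 has only a limit of > 100000 nM in this assay. Compound 2 has the same kind of result, and compound 1 adds no number to compare.

Compound 4 `CC(C)C[C@@H](NC(=O)OC(C)(C)C)C(=O)N1CCC[C@@H]1C(=O)N1[C@H](C(=O)OCc2ccccc2)[C@H]1C(=O)OCc1ccccc1` is built from compound 3 by one change, isobutyl in place of hydrogen on a saturated chain carbon bound to an amide-type nitrogen and a carbonyl carbon.

Only one measured step bears on this comparison, and it concerns a different kind of change, as shown by the fact that compounds 2 and 3 differ only in the configuration as drawn. That step, a step that the two limits leave unreadable from compound 2 to compound 3, has no readable size. The record therefore amounts to the limit of > 100000 nM in this assay, at which 2 of the 3 values shown sit, and it contains no measured effect of adding isobutyl. The expectation for compound 4 rests on compound 3, with its limit of > 100000 nM.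

No change beyond the scatter is expected, and the estimated step is a number no higher from compound 3 to compound 4 (the limit leaves the size open). For compound 4 the expected value is 100000 nM, with an estimated range from 40000 nM to 200000 nM.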

Compound 4, half-maximal inhibitory concentration: > 100000 nM
Compound 4: no number, only a limit; the forecaster's own chance of this, stated with the estimate: 80%; the middle value sits exactly at the limit.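

In this assay compound 4 gives > 100000 nM, which is a limit and not a number. Within the data shown here, compound 3 also has only a limit, and no step between compound 3 and compound 4 can be read. The compounds shown leave open what exact value any of them has in this assay, and whether isobutyl in place of hydrogen changes that value at all.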